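Swapping a pyridine for a phenyl on the amide

A few compounds are considered here, and "the series" means these few. Any claim that something is new, unique, unknown or untested is made for them only; others in the source may bear on it.

Compound 1, with the structure `COc1ccc(S(=O)(=O)Oc2ccccc2NC(=O)c2ccccn2)cc1`, was tested in a functional assay on NCI-H460 cells (Homo sapiens) for antiproliferative activity (on this read-out lower numbers stand for stronger inhibition and higher numbers for weaker inhibition), and gives 300 nM, the lowest of the two numbers recorded. Among the compounds with values here, its only measured neighbour is compound 2, `COc1ccc(S(=O)(=O)Oc2ccccc2NC(=O)c2ccc(F)cc2)cc1`, which in this assay gives 550 nM; the change a 1.8-fold higher number from compound 1 to compound 2 (0.26 log units; within the scatter) is too small to count as a real difference. The compound now to be tested is compound 3, `COc1ccc(S(=O)(=O)Oc2ccccc2NC(=O)c2ccccc2)cc1`. It differs from compound 1 only at one place: phenyl in place of pyridin-2-yl on a carbonyl carbon. Within the data shown here, the single step that bears on this change is the one to compound 2, where an aromatic ring without the ring nitrogen also replaced the pyridin-2-yl group and the number hardly moved. No shift beyond the scatter is therefore expected in this assay for compound 3. Compound 3 is estimated to give 500 nM, within 200 nM to 1500 nM, which means an expected step of a 1.7-fold higher number from compound 1 to compound 3 (0.22 log units; within the scatter).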

Compound 3, half-maximal inhibitory concentration: 410 nM
Beside the measured number, compound 3's estimate is 1.2-fold (0.09 log units) above it, and the stated range covers the measured number.
By their numbers in this assay, from the lowest: compounds 1, 3 and 2 (each within the scatter of the next).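

In this assay, taking out the ring nitrogen with nothing else altered gives a 1.4-fold higher number from compound 1 to compound 3 (0.14 log units; within the scatter) and so leaves the number within the scatter, which means the hydrogen-bond acceptor that leaves with the pyridin-2-yl group is not shown to matter on this read-out. Compound 2 differed from compound 1 by a fluoro as well as by the missing ring nitrogen, and the fluoro can now be read alone: hydrogen in its place gives a 1.3-fold lower number from compound 2 to compound 3 (0.13 log units; within the scatter) and again no real difference. No measurement here accounts for how little these swaps change the number.

Still open, from the compounds shown here alone, is whether a pyridin-3-yl group would behave like these rings. Also open, going by these compounds, is whether a cyclohexyl ring, a short alkyl chain or an aromatic ring carrying an amine or a carboxylic acid on this carbonyl carbon would move the number beyond the scatter.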